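Phenoxy Ester Variant of a Chlorinated Quinolinone Core

The compounds below may be only part of what the source reports. "The series", "measured", "known", "first", "only" and "open" are said of these compounds alone.

Compound 1 `CC(=O)OCCc1c(-c2ccccc2Cl)c2cc(Cl)ccc2[nH]c1=O` is the smallest ester of the three measured here. In an ADME assay on HepG2 2.2.15 cells (Homo sapiens) for cytotoxicity (a lower number here means that less compound is tolerated, a higher number that more compound is tolerated), compound 1 gives 27000 nM, the lowest of the three numbers. Compound 2 `CCCC(=O)OCCc1c(-c2ccccc2Cl)c2cc(Cl)ccc2[nH]c1=O` gives 52000 nM, and the step of a 1.9-fold higher number from compound 1 to compound 2 (0.28 log units; within the scatter) stays within the scatter. Compound 3 `O=C(OCCc1c(-c2ccccc2Cl)c2cc(Cl)ccc2[nH]c1=O)c1ccc([N+](=O)[O-])cc1` gives 1600000 nM, reached by the step of a 59-fold higher number from compound 1 to compound 3 (1.77 log units; beyond the scatter), and from compound 2 the step of a 31-fold higher number from compound 2 to compound 3 (1.49 log units; beyond the scatter) is also large. Compound 4 `O=C(COc1ccccc1)OCCc1c(-c2ccccc2Cl)c2cc(Cl)ccc2[nH]c1=O` is not yet measured; it differs from compound 1 as phenoxy in place of hydrogen on a saturated chain carbon bound to a carbonyl carbon. The change sits at the same saturated chain carbon bound to a carbonyl carbon as in the step from compound 1 to compound 2, which was small, yet it brings in an aromatic ring, as the step from compound 1 to compound 3 did, which was large. Weighing both, a moderate rise in the tolerated concentration is expected, a 4.1-fold higher number from compound 1 to compound 4 (0.61 log units; beyond the scatter). For compound 4 in this assay the estimate is 110000 nM, with a range from 30000 nM to 450000 nM.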

Compound 4, half-maximal cytotoxic concentration: 81000 nM
Estimate against measurement, compound 4: 1.4-fold (0.13 log units) above, and the stated range covers the measured number.
By their numbers in this assay, from the lowest: compounds 1, 2 and 4 (each within the scatter of the next, the first and the last beyond it); then compound 3.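

Phenoxy at the saturated chain carbon bound to a carbonyl carbon brings in an aromatic ring, yet in this assay it gives only a modest rise (a 3.0-fold higher number from compound 1 to compound 4 (0.48 log units; beyond the scatter)). At this carbon, phenoxy and ethyl cannot be told apart (a 1.6-fold higher number from compound 2 to compound 4 (0.19 log units; within the scatter)). An aromatic ring in the ester is therefore not enough for the large number seen for compound 3, which carries 4-nitrophenyl on the carbonyl carbon itself (a 20-fold lower number from compound 3 to compound 4 (1.30 log units; beyond the scatter)).

No measurement shown here explains these differences. As far as these compounds go, it remains open whether a plain phenyl on the carbonyl carbon would give a number like that of compound 3, or whether the nitro group is needed, and how an amine or a carboxylic acid on the chain carbon would behave.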